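Swapping the Aryl Group on a Quinoline Sulfone

The source may hold more compounds than are shown below. What is called first, only, known or untested is meant among the compounds shown, and "the series" means these compounds.

Compound 1, `Cc1ccc(S(=O)(=O)c2cnc3cc(F)ccc3c2N2CCC(C)CC2)cc1C`: 90%
Compound 2, `Cc1ccc2ncc(S(=O)(=O)c3ccc(Cl)cc3)c(N3CCC(C)CC3)c2c1`: 79%

Both were tested in an assay on isolated protein for displacement of a labelled ligand from metabotropic glutamate receptor 5 (Homo sapiens), with a stated time of 60 min, tested at 1 uM; on this read-out lower numbers stand for less inhibition and higher numbers for more inhibition at the one concentration tested (going by the name of the read-out). Compound 1 gives 90%, the higher of the two numbers; the nearest, compound 2, lies lower by a gap beyond the usual scatter. Compound 3, `COc1cccc(S(=O)(=O)c2cnc3cc(F)ccc3c2N2CCC(C)CC2)c1`, has not been measured. It differs from compound 1 in a single place: 3-methoxyphenyl in place of 3,4-dimethylphenyl on a sulfonyl sulfur. Going by the values given here, no measured pair shows a comparable change, so the size of this step is uncertain. Compound 3 is expected to give 75%, in a range from 50% to 92%. The expected step of a number 15 percentage points lower from compound 1 to compound 3 (beyond the scatter) is a modest loss, possibly none beyond the scatter.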

Compound 3, a percentage reported as inhibition, at one concentration (the size of the read-out at that concentration, not a potency): 90%
The estimate for compound 3 lay 15 percentage points below the measured number; low and high end bracket the measured number.
By their numbers in this assay, from the lowest: compound 2; then compounds 1 and 3 (each within the scatter of the next).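

Putting 3-methoxyphenyl in place of 3,4-dimethylphenyl on a sulfonyl sulfur gives no change at the digits printed from compound 1 to compound 3 (within the scatter) in this assay. The aryl group here therefore need not be carbon only: the entering group carries an oxygen and a hydrogen-bond acceptor, yet the two numbers match within the scatter. Nothing available explains why these two groups match.

On these data alone, it remains open how an aryl group bearing an amine or a carboxylic acid would behave on the sulfonyl sulfur. A reading at one concentration also leaves open whether compound 1 and compound 3 match in potency.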